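The source may report more compounds than this note shows. Statements on the series, on what has been measured and on what is new or still open speak of the compounds shown alone.

Series notes. Among the measured compounds shown here, compound 1 `O=C(N/N=C/c1ccc(Cl)cc1Cl)Nc1cccc2ccccc12` and compound 2 `COc1cc(/C=N/NC(=O)Nc2cccc3ccccc23)ccc1O` are the two measured so far in a functional assay on the whole organism (strain Swiss albino) with Mus musculus as the target, in the maximal electroshock model, with a stated time of 0.5 h; a higher number here means that more compound is needed for the effect, a lower number that less compound is needed; compound 1 gives 100 mg/kg and compound 2 gives 300 mg/kg. Among these two numbers compound 2 stands highest, and its nearest neighbour is compound 1, whose number is the lower one; that gap lies beyond the scatter. For the measured compounds named here, no pair of measured compounds differs in one place only, so the effect of a single change has not yet been seen.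

Compound 3 `O=C(N/N=C/c1ccc(O)cc1)Nc1cccc2ccccc12` is the next to go into this assay. Relative to compound 2 the change is hydrogen in place of methoxy on an aromatic carbon, the hydrogen entering on an aromatic carbon of a six-membered aromatic ring of carbon only, ortho to a hydroxy group and meta to a large group. Compound 1 carries neither a hydroxy nor a methoxy group on that ring, so nothing measured shows what this change does on its own. The expected step is small, leaning toward a lower number but probably none beyond the scatter, as a 1.5-fold lower number from compound 2 to compound 3 (0.18 log units; within the scatter) expresses. Compound 3 is therefore estimated at 200 mg/kg, within a range from 100 mg/kg to 600 mg/kg.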

Compound 3, minimum effective dose: 100 mg/kg
For compound 3 the middle estimate is 2.0-fold (0.30 log units) above the measured one, and the stated range covers the measured number.
By their numbers in this assay, from the lowest: compounds 1 and 3 (each within the scatter of the next); then compound 2.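

In this assay the series now shows its first single-place change: hydrogen in place of methoxy on an aromatic carbon, ortho to a hydroxy group and meta to a large group, gives a 3.0-fold lower number from compound 2 to compound 3 (0.48 log units; beyond the scatter) (a modest step). The methoxy at this place therefore goes with needing more compound, at least on a ring that also carries the hydroxy group. The second step, 4-hydroxyphenyl in place of 2,4-dichlorophenyl on a carbon with a double bond to nitrogen, reads no change at the digits printed from compound 1 to compound 3 (within the scatter), so these two groups are not told apart in this read-out, and nothing measured on these compounds accounts for either step.

Open, as far as these compounds go, is whether the methoxy step holds on a ring without the hydroxy group, and whether an ethoxy group, an amine or a carboxylic acid at the same aromatic carbon would sit with compound 2 or with compound 3. Also open, from the compounds shown here alone, is whether any change on the other side of the shared core moves the number at all.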